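The source may hold more compounds than are shown below. What is called first, only, known or untested is meant among the compounds shown, and "the series" means these compounds.

Measured so far:
Compound 1 `Fc1ccc2nc(-n3ccnn3)n(C3CC3)c2c1` — 9070 nM
Compound 2 `CCc1ncncc1-c1nc2cc(F)c(F)cc2n1C1CC1` — 3330 nM

Both compounds were tested in an ADME assay on cells for inhibition of cytochrome P450 11B1, mitochondrial (Homo sapiens), read by HPLC, with a stated time of 60 min; a lower number here means a stronger inhibitor, a higher number a weaker inhibitor. Compound 2 gives the lower of the two numbers; compound 1 is the nearest point of comparison, and the gap between them lies beyond the scatter of repeated measurements, so compound 2 is the stronger inhibitor of the two.

Compound 3 `Fc1cc2nc(-c3cncnc3C(F)(F)F)n(C3CC3)c2cc1F` has not yet been measured. It differs from compound 2 in one place: trifluoromethyl in place of ethyl on an aromatic carbon. For the measured compounds named here, no measured pair shows this particular change, so its effect on this assay cannot be read from a step already seen; it is a guess resting on compound 2 alone.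

The expectation is a step of modest size, within or only slightly beyond the scatter, in either direction, so the expected step is a 1.1-fold higher number from compound 2 to compound 3 (0.02 log units; within the scatter). On that basis compound 3 is estimated at 3500 nM, with a range from 1200 nM to 10000 nM.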

Compound 3, half-maximal inhibitory concentration: 4770 nM
The estimate for compound 3 lay 1.4-fold (0.13 log units) below the measured number, and the stated range covers the measured number.
By their numbers in this assay, from the lowest: compounds 2, 3 and 1 (each within the scatter of the next, the first and the last beyond it).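

In this assay, trifluoromethyl in place of ethyl on this aromatic carbon gives a 1.4-fold higher number from compound 2 to compound 3 (0.16 log units; within the scatter). For the compounds shown here, this is the first direct comparison at this position, and it shows that the assay does not separate these two groups here, even though the heavy-atom count of the group rises from 2 to 4 and the ethyl carbons give way to fluorine-bearing trifluoromethyl. No measurement at hand bears on why the two groups read alike.

As far as these compounds go, it remains open whether this position responds to anything at all, since a methoxy group, an amine or a longer chain such as propyl could give a step beyond the scatter. A single pair also cannot show whether the same exchange would read alike on a different core.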